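The compounds below may be only part of what the source reports. "The series", "measured", "known", "first", "only" and "open" are said of these compounds alone.

Going by the values given here, in a functional assay on KM12 cells (Homo sapiens) for inhibition, read by sulforhodamine B assay, with a stated time of 48 h, tested at 10 uM (on this read-out higher numbers stand for more inhibition of growth at the one concentration tested and lower numbers for less inhibition of growth), compound 1 `COc1ccc(-c2nc3sc(-c4ccccc4)cn3n2)cc1` gives 70%, the highest of the three numbers so far and clearly beyond the usual scatter of the other two. The core of compound 1 recurs in compound 2 `COc1cc(-c2nc3sc(-c4ccccc4)cn3n2)cc(OC)c1OC`, which gives 14%. Compound 3 `COc1cc(-c2nc(N)n(CC(=O)Nc3ccc(/C(C)=N\O)cc3)n2)cc(OC)c1OC`, built differently, gives 2.75%.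

The next compound to consider is compound 4 `COc1ccc(-c2nc3sc(-c4ccc(Cl)cc4)cn3n2)cc1`, which is compound 1 with one change: chloro in place of hydrogen on an aromatic carbon. In words, a phenyl becomes a 4-chlorophenyl. Among the compounds with values here, no two measured compounds differ in just one place, so the data show no direct precedent for the size of this step. A single chloro in place of hydrogen is a small edit, so the expectation in this assay is a modest drop or no change beyond the scatter. Still, the gap between compound 1 at 70% and compound 2 at 14% shows that numbers within this family can lie far apart, so a wide range is prudent. The expected change is a number 8 percentage points lower from compound 1 to compound 4 (within the scatter). The estimated value for compound 4 is 62%, within a range of 32% to 85%.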

Compound 4, percent growth inhibition at one concentration: 45.3%
Compound 4: middle estimate off by 16.7 percentage points, on the high side, within the range that was stated.
By their numbers in this assay, from the lowest: compound 3; then compound 2; then compound 4; then compound 1.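

Going by these compounds alone, this is the first step that changes only one place, and so the first direct look at this position. In this assay, placing a chloro in place of hydrogen on an aromatic carbon, para to a large group, turns a phenyl into a 4-chlorophenyl and gives a number 24.7 percentage points lower from compound 1 to compound 4 (beyond the scatter). The position is therefore sensitive to even one added chlorine atom, although nothing available explains why the number falls.

A single substituent cannot show whether this drop is particular to chloro or would follow from any group placed here. A fluoro, a methoxy or an amine on the same carbon would help separate those two readings, and so would a chloro on another carbon of the same ring.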